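This account rests on a few compounds, and the source may have more. Where it says the series, first, only, none or still open, it means among the compounds named here.

Measured in a functional assay on SNB-19 cells (Homo sapiens) for inhibition, read by sulforhodamine B assay, with a stated time of 48 h; a lower number here means a stronger inhibitor of growth, a higher number a weaker inhibitor of growth:
compound 1 `Nc1cc(N)c2nc(-c3ccccc3)c(Oc3ccc(Cl)c(Cl)c3)nc2c1`: 52500 nM
compound 2 `Nc1cc(N)c2nc(-c3ccccc3)c(NCc3ccc(Cl)c(Cl)c3)nc2c1`: 51300 nM
compound 3 `CCOC(=O)[C@H](CCC(=O)O)NC(=O)c1ccc(Sc2nc3cc(N)cc(N)c3nc2-c2ccccc2)cc1`: a limit, < 100000 nM

In this assay compound 2 gives 51300 nM and compound 1 gives 52500 nM; the two sit within the usual scatter of each other. For compound 3 the value < 100000 nM is a limit of this assay rather than a number. Compound 4 `COc1ccc(CNc2nc3cc(N)cc(N)c3nc2-c2ccccc2)cc1` differs from compound 2 by 4-methoxyphenyl in place of 3,4-dichlorophenyl on a saturated chain carbon bound to a nitrogen on an aromatic ring. Among the measured compounds shown here, no step between measured compounds bears on this change, and the measured numbers all sit at weak inhibition. Compound 4 is therefore expected to remain in that region, with a step of a 1.2-fold higher number from compound 2 to compound 4 (0.07 log units; within the scatter) not beyond the scatter. Compound 4 is estimated at 60000 nM, in a range from 20000 nM to 150000 nM.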

Compound 4, concentration for total growth inhibition: < 100000 nM
Compound 4: no number, only a limit; the forecaster's own chance of this, stated with the estimate: 30%; the middle value is on the limit's open side.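

In this assay compound 4 gives < 100000 nM, which is a limit and not a number. Among the compounds shown here, no step from compound 2 to compound 4 can therefore be read. The compounds shown leave open whether 4-methoxyphenyl in place of 3,4-dichlorophenyl changes growth inhibition at all.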